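A few compounds are considered here, and "the series" means these few. Any claim that something is new, unique, unknown or untested is made for them only; others in the source may bear on it.

Compound 3 `O=S(=O)(c1ccccc1Cl)c1cn(C2CCCNC2)c2ncccc12` gives 3.7 nM in an assay on HeLa cells for displacement of a labelled ligand from 5-hydroxytryptamine receptor 6 (Homo sapiens) (on this read-out higher numbers stand for weaker inhibition and lower numbers for stronger inhibition), the highest of the three numbers recorded. Its nearest neighbour is compound 1 `CN1CCC(n2cc(S(=O)(=O)c3ccccc3Cl)c3cccnc32)C1`, which gives 2.2 nM in this assay; the step of a 1.7-fold higher number from compound 1 to compound 3 (0.23 log units; within the scatter) lies within the scatter. Among the compounds with values here, compound 2 `CCN1CCC(n2cc(S(=O)(=O)C3=C(Cl)NC4SC=CN34)c3cccnc32)C1` gives 1.4 nM in this assay, and the two values of compound 3 and compound 2 differ beyond the scatter; no single-point step connects them.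

Compound 4 `O=S(=O)(c1ccccc1F)c1cn(C2CCCNC2)c2ncccc12` differs from compound 3 by fluoro in place of chloro on an aromatic carbon. Within the data shown here, no measured step touches this position: the only measured step, a 1.7-fold higher number from compound 1 to compound 3 (0.23 log units; within the scatter), concerns the group on the aromatic nitrogen. With nothing to anchor the change, compound 4 is expected to stay close to compound 3, with a 1.2-fold higher number from compound 3 to compound 4 (0.09 log units; within the scatter). The estimate for compound 4 in this assay is therefore 4.5 nM, within 1.5 nM to 14 nM.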

Compound 4, inhibition constant: 2 nM
Compound 4: the middle estimate sits 2.3-fold (0.35 log units) above what was measured; measured number inside the range.
By their numbers in this assay, from the lowest: compounds 2, 4, 1 and 3 (each within the scatter of the next, the first and the last beyond it).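

The aromatic carbon ortho to a large group now has a measured step: on the piperidin-3-yl series member, fluoro in place of chloro in this assay gives a change within the scatter (a 1.9-fold lower number from compound 3 to compound 4 (0.27 log units; within the scatter)). This position therefore tolerates the exchange of 2-chlorophenyl for 2-fluorophenyl without a readable loss or gain. Nothing available explains this result.

As far as these compounds go, whether the same exchange reads alike with the 1-methylpyrrolidin-3-yl group of compound 1 remains open. So does the reading in this assay for a methoxy group, a nitrile or an amine at this position.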